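The compounds below may be only part of what the source reports. "The series", "measured", "known", "first", "only" and "open" are said of these compounds alone.

Measured so far:
compound 1, `CC1(C)C(=O)Nc2nc(-n3nc(Cc4ccccc4F)c4cc(Cl)ccc43)nc(N)c21` — 18000 nM
compound 2, `COC(=O)N(C)c1c(N)nc(-n2nc(Cc3ccccc3F)c3cc(F)ccc32)nc1N` — 960 nM
compound 3, `COC(=O)Nc1c(N)nc(-n2nc(Cc3c(F)ccc(F)c3F)c3cc(Cl)ccc32)nc1N` — 670 nM

Of the compounds shown here, three built on a shared core have been measured in an assay on CHO cells for activation of soluble guanylate cyclase alpha1/beta1 complex (Homo sapiens), read by cGMP accumulation; a higher number here means that more compound is needed for the effect, a lower number that less compound is needed. Compound 1 gives 18000 nM, the highest of the three numbers. Compound 2 gives 960 nM and compound 3 gives 670 nM, each lower than the number for compound 1 by more than the usual scatter. Compounds 2 and 3 differ from compound 1 in several places at once, so no single structural step can be read from these pairs.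

Compound 4 is `CC1(C)C(=O)Nc2nc(-n3nc(CCC(F)(F)F)c4cc(Cl)ccc43)nc(N)c21` and has not yet been measured in this assay. It differs from compound 1 in one place: 2,2,2-trifluoroethyl in place of 2-fluorophenyl on a saturated chain carbon bound to an aromatic carbon. All three measured compounds carry an aromatic ring on the saturated chain carbon bound to an aromatic carbon, so the measured data give no guidance on what follows when that ring is replaced by a group with no ring. With only the structural change to go on, a modest step toward a higher number is expected, a 1.7-fold higher number from compound 1 to compound 4 (0.22 log units; within the scatter), though a step within the scatter cannot be excluded. Compound 4 is therefore estimated to give 30000 nM in this assay, with a range from 10000 nM to 100000 nM.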

Compound 4, half-maximal effective concentration: 87000 nM
The estimate for compound 4 lay 2.9-fold (0.46 log units) below the measured number; low and high end bracket the measured number.
By their numbers in this assay, from the lowest: compounds 3 and 2 (each within the scatter of the next); then compound 1; then compound 4.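

In this assay, within the data shown here, exchanging 2-fluorophenyl for 2,2,2-trifluoroethyl on a saturated chain carbon bound to an aromatic carbon gives a 4.8-fold higher number from compound 1 to compound 4 (0.68 log units; beyond the scatter), the first step in this set that can be read at a single place. It shows that this position is sensitive to what it carries, since the change alone moves the number beyond the scatter, and that the change from 2-fluorobenzyl to 3,3,3-trifluoropropyl goes toward more compound being needed for the effect. No measurement shown here explains the size of this step or separates the contribution of the departing ring from that of the entering fluorines.

The compounds shown leave open whether a plain propyl chain, with no fluorine, or a cyclohexylmethyl group, which keeps a ring that is not aromatic, would stand nearer to compound 1 or to compound 4. They also leave open whether the same exchange would bring a step of similar size on the differing frameworks of compound 2 and compound 3, which carry a methyl carbamate group in place of the lactam of compound 1.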